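Chloro to methyl on the benzyl ring: clearance notes

The source may report more compounds than this note shows. Statements on the series, on what has been measured and on what is new or still open speak of the compounds shown alone.

Compound 1 `COc1ccc(Cl)cc1Cn1c(C(=O)NCC(C)(C)CO)cc2cc(C#N)ccc21` gives 83 mL.min-1.g-1 in an in vitro ADME assay on microsomes from liver (Homo sapiens) for metabolic stability, using NADPH; on this read-out lower numbers stand for slow clearance and higher numbers for fast clearance. Compound 2 `COc1ccc(C)cc1Cn1c(C(=O)NCC(C)(C)CO)cc2cc(C#N)ccc21` differs from it by methyl in place of chloro on an aromatic carbon; in this assay compound 2 gives 191 mL.min-1.g-1, the step being a 2.3-fold higher number from compound 1 to compound 2 (0.36 log units; beyond the scatter). Compound 3 `Cc1ccc(Cl)cc1Cn1c(C(=O)NCC(C)(C)CO)cc2cc(C#N)ccc21` carries a different core: against compound 1 the difference is methyl in place of methoxy on an aromatic carbon, with a 1.4-fold higher number from compound 1 to compound 3 (0.16 log units; within the scatter), and in this assay compound 3 gives 119 mL.min-1.g-1. Compound 2 and compound 3 differ by the whole ring, with a 1.6-fold lower number from compound 2 to compound 3 (0.21 log units; within the scatter).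

Compound 4 `Cc1ccc(C)c(Cn2c(C(=O)NCC(C)(C)CO)cc3cc(C#N)ccc32)c1` is not yet measured. It stands to compound 3 as compound 2 stands to compound 1: the change is methyl in place of chloro on an aromatic carbon. The surroundings are not identical: in compound 1 the exchanged carbon is para to a methoxy group (2 heavy atoms), in compound 3 it is para to a methyl group (1 heavy atom), so this is the same kind of change rather than the same change. For compound 4 in this assay a step of about a 1.9-fold higher number from compound 3 to compound 4 (0.29 log units; within the scatter) is expected, beside the earlier one, because the same exchange gave a 2.3-fold higher number from compound 1 to compound 2 (0.36 log units; beyond the scatter). The differing group around the place is a reason to keep the range wide. Compound 4 is thus estimated at 230 mL.min-1.g-1, with a likely span from 130 mL.min-1.g-1 to 420 mL.min-1.g-1.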

Compound 4, intrinsic clearance in microsomes: 257 mL.min-1.g-1
Compound 4: middle estimate off by 1.1-fold (0.05 log units), on the low side, within the range that was stated.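

In this assay the exchange of chloro for methyl carries over from the core of compound 1 to the core of compound 3, with a 2.2-fold higher number from compound 3 to compound 4 (0.33 log units; beyond the scatter) standing close to the earlier step: the same change on two cores in this assay, a 2.3-fold higher number (0.36 log units; beyond the scatter) from compound 1 to compound 2 and a 2.2-fold higher number (0.33 log units; beyond the scatter) from compound 3 to compound 4, 1.1-fold (0.03 log units) apart, within the scatter of two such steps. The exchange of methoxy for methyl also reads alike on the two backgrounds, with a 1.3-fold higher number from compound 2 to compound 4 (0.13 log units; within the scatter) matching its earlier counterpart: the same change on two cores in this assay, a 1.4-fold higher number (0.16 log units; within the scatter) from compound 1 to compound 3 and a 1.3-fold higher number (0.13 log units; within the scatter) from compound 2 to compound 4, 1.1-fold (0.03 log units) apart, within the scatter of two such steps. Going by these compounds alone, with both exchanges made, the ring change gives a 3.1-fold higher number from compound 1 to compound 4 (0.49 log units; beyond the scatter), but this agreement rests on only two pairs for each exchange, all sharing the same amide chain and nitrile, so it does not show that either step would hold on a more distant core, nor does it explain why the numbers move.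

The compounds shown leave open how a fluoro or a trifluoromethyl group would read at the exchanged place. Also open, going by these compounds, is whether the methyl-for-chloro step survives on a core with a carboxylic acid or an amine on the amide chain.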